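This account rests on a few compounds, and the source may have more. Where it says the series, first, only, none or still open, it means among the compounds named here.

Measured so far in a functional assay on isolated protein for inhibition of Glucose-dependent insulinotropic receptor (Rattus norvegicus), read by HTRF and cAMP accumulation; on this read-out higher numbers stand for an effect only at larger amounts of compound and lower numbers for an effect already at smaller amounts:
compound 1 `Cc1nc(S(C)(=O)=O)ccc1Oc1ncnc(OC2CCN(C(=O)SC3(C)CC3)CC2)c1F`: 166 nM
compound 2 `Cc1nc(S(C)(=O)=O)ccc1Oc1ncnc(OC2CCN(C(=O)C(C)(C)F)CC2)c1F`: 296 nM
compound 3 `Cc1nc(S(C)(=O)=O)ccc1Oc1ncnc(OC2CCN(C(=O)C3(F)CCC3)CC2)c1F`: 123 nM

Compound 3 holds the lowest of the three numbers. Its gap to compound 1 is small, a 1.3-fold lower number from compound 1 to compound 3 (0.13 log units; within the scatter), so the two cannot be ranked; its gap to compound 2 is clearer, a 2.4-fold lower number from compound 2 to compound 3 (0.38 log units; beyond the scatter).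

Next in line is compound 4 `Cc1nc(S(C)(=O)=O)ccc1Oc1ncnc(OC2CCN(C(=O)c3noc(C(C)(C)F)n3)CC2)c1F`. The change from compound 3 is a group of 9 heavy atoms (5 carbon, 2 nitrogen, 1 oxygen, 1 fluorine; one five-membered aromatic ring with 3 hetero atoms) in place of a group of 5 heavy atoms (4 carbon, 1 fluorine; one four-membered non-aromatic ring of carbon only), on a carbonyl carbon.

All three measured steps sit on this same carbonyl carbon: a 1.8-fold higher number from compound 1 to compound 2 (0.25 log units; within the scatter), a 1.3-fold lower number from compound 1 to compound 3 (0.13 log units; within the scatter) and a 2.4-fold lower number from compound 2 to compound 3 (0.38 log units; beyond the scatter). Together they span a narrow band, with only one of them beyond the scatter. None of them introduces an aromatic ring or a group as large as the one entering here, so the present step is covered only loosely. On what is known, a change near the scatter is the likeliest outcome, with the wider group leaning, if anything, toward a somewhat higher number.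

Compound 4 is therefore expected at about 220 nM, within 70 nM to 700 nM. This estimate corresponds to a 1.8-fold higher number from compound 3 to compound 4 (0.25 log units; within the scatter), a step expected to stay close to the scatter.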

Compound 4, half-maximal effective concentration: 103 nM
For compound 4 the middle estimate is 2.1-fold (0.33 log units) above the measured one, within the range that was stated.
By their numbers in this assay, from the lowest: compounds 4, 3, 1 and 2 (each within the scatter of the next, the first and the last beyond it).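

In this assay, the carbonyl carbon accepts a group of 9 heavy atoms with a five-membered aromatic ring with 3 hetero atoms, and the read-out does not separate it from either group of 5 heavy atoms: a 1.2-fold lower number from compound 3 to compound 4 (0.08 log units; within the scatter) and a 1.6-fold lower number from compound 1 to compound 4 (0.21 log units; within the scatter). It is separated only from the group of 4 heavy atoms with no ring, and modestly at that: a 2.9-fold lower number from compound 2 to compound 4 (0.46 log units; beyond the scatter). No measurement is at hand that explains this outcome.

The compounds shown leave open whether a phenyl ring, with no hetero atoms, would read the same on this carbonyl carbon, and what an amine or a carboxylic acid on the aromatic ring would do. They also leave open how any of these groups behaves once the shared core is altered.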